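Series notes: from compound 3 to compound 4

A few compounds are considered here, and "the series" means these few. Any claim that something is new, unique, unknown or untested is made for them only; others in the source may bear on it.

Measured so far:
compound 1 `CC(C)=CCOc1ccc2c(c1)OC(c1ccc(Cl)cc1)CC2=O`, 6970 nM
compound 2 `CC(C)=CCOc1cc(O)c2c(c1)OC(c1cccc(F)c1)CC2=O`, 7240 nM
compound 3 `CC(C)=CCOc1cc(O)c2c(c1)OC(c1ccc(F)cc1)CC2=O`, 6060 nM

In a functional assay (a lower number here means a stronger inhibitor, a higher number a weaker inhibitor), compound 3 gives 6060 nM, a number that lies within the scatter of both compound 1 and compound 2, so no ordering among the three can be read from it. Among the compounds with values here, the only single-place step in hand, a 1.2-fold lower number from compound 2 to compound 3 (0.08 log units; within the scatter), is itself within the scatter. Compound 4 `CC(C)=CCOc1cc(O)c2c(c1)OC(c1ccc(Cl)cc1)CC2=O` is the next entry; relative to compound 3 the change is chloro in place of fluoro on an aromatic carbon. Within the data shown here, no measured step shows this exchange on its own. Compound 1 carries the entering group but differs from compound 3 in a second place as well, and its value sits within the scatter of compound 3. A step within the scatter is therefore expected, a 1.1-fold higher number from compound 3 to compound 4 (0.03 log units; within the scatter). For compound 4 the estimate is 6500 nM, with a range from 3000 nM to 13000 nM.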

Compound 4, half-maximal inhibitory concentration: 7020 nM
Compound 4: middle estimate off by 1.1-fold (0.03 log units), on the low side, and the stated range covers the measured number.
By their numbers in this assay, from the lowest: compounds 3, 1, 4 and 2 (each within the scatter of the next).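

With chloro in place of fluoro on the aromatic carbon, the exchange now reads on its own in this assay (a 1.2-fold higher number from compound 3 to compound 4 (0.06 log units; within the scatter)), and the 4-chlorophenyl in place of 3-fluorophenyl step also stays inside the scatter (a 1.0-fold lower number from compound 2 to compound 4 (0.01 log units; within the scatter)). Within the data shown here, with chloro held fixed, hydroxy in place of hydrogen can also be read singly for the first time (a 1.0-fold higher number from compound 1 to compound 4 (0.00 log units; within the scatter)), again inside the scatter. From the compounds shown here alone, whether a nitrile or an amine on that aromatic carbon would leave the scatter remains open. No supporting measurement bears on these results.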